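Adding a methyl to the pyridine of a thiosemicarbazide

The compounds below may be only part of what the source reports. "The series", "measured", "known", "first", "only" and "open" are said of these compounds alone.

Compounds measured so far:
- compound 1, `Cc1ccnc(/C(N)=N/NC(=S)N2CCSCC2)c1`: 15500 nM
- compound 2, `N/C(=N\NC(=S)N1CCCCC1)c1ccccn1`: 3800 nM

Of the compounds shown here, two sharing the same core have been tested in a functional assay on HeLa cells (Homo sapiens) for cytotoxicity, read by MTT assay, with a stated time of 72 h; a lower number here means a stronger inhibitor, a higher number a weaker inhibitor. Compound 2 gives 3800 nM, the lower of the two numbers. Compound 1 gives 15500 nM, a higher number, and the gap between the two lies beyond the usual scatter. Compound 1 differs from compound 2 in more than one place, so the two values alone do not tell which part of the structure is behind the gap.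

Compound 3, `Cc1ccnc(/C(N)=N/NC(=S)N2CCCCC2)c1`, has not yet been measured. It departs from compound 2 by a single change: methyl in place of hydrogen on an aromatic carbon. Among the compounds with values here, no measured pair shows this change on its own, so no step for it is known. The expectation is a small shift toward a higher number, since compound 1, which also carries the methyl, gives 15500 nM, but with wide uncertainty because compound 1 differs in a second place as well. The step from compound 2 to compound 3 is estimated at a 1.6-fold higher number from compound 2 to compound 3 (0.20 log units; within the scatter). Compound 3 is thus expected to give about 6000 nM in this assay, most likely between 2000 nM and 18000 nM.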

Compound 3, half-maximal inhibitory concentration: 7700 nM
Compound 3: the middle estimate sits 1.3-fold (0.11 log units) below what was measured; the range from low to high includes it.
By their numbers in this assay, from the lowest: compound 2; then compounds 3 and 1 (each within the scatter of the next).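

In this assay, within the data shown here, methyl in place of hydrogen on the aromatic carbon opposite the ring nitrogen gives a 2.0-fold higher number from compound 2 to compound 3 (0.31 log units; beyond the scatter), which shows this one change on its own for the first time, as a modest loss of strength. Compound 3 also completes a second single-change pair, with piperidin-1-yl in place of thiomorpholin-4-yl on the thiocarbonyl carbon, and that pair shows a 2.0-fold lower number from compound 1 to compound 3 (0.30 log units; within the scatter), so this exchange cannot be told apart from repeat-to-repeat variation in the measurement. Of these two single changes, only the methyl step lies beyond the scatter, and it does so narrowly, so the position appears to respond to even one added carbon, but this rests on a single small step.

As far as these compounds go, whether an ethyl chain, a methoxy group or an amine on this same carbon would push the number further, or reverse the direction of the step, remains open. No measurement among those shown offers a reason for either step.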